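Chloro in place of methoxy on compound 2

The compounds below may be only part of what the source reports. "The series", "measured", "known", "first", "only" and "open" are said of these compounds alone.

Measured so far in a functional assay on KYSE-70 cells for antiproliferative activity against KYSE-70 cell line (Homo sapiens), read by MTT assay, with a stated time of 72 h; a lower number here means a stronger inhibitor, a higher number a weaker inhibitor
Compound 1 `O=C(Nc1ccc(F)cc1)c1ccnc2cc(Br)ccc12` gives > 20000 nM
Compound 2 `COc1ccc(NC(=O)c2cc(=O)[nH]c3cc(Br)ccc23)cc1` gives > 20000 nM

For compound 2 the value > 20000 nM is a limit of the assay and not a number. Among the measured compounds shown here, the series so far offers only the limit of > 20000 nM in this assay, at which 2 of the 2 values shown sit, and holds no measured step. Compound 3 `O=C(Nc1ccc(Cl)cc1)c1cc(=O)[nH]c2cc(Br)ccc12` is next. The change chloro in place of methoxy on an aromatic carbon puts chloro in place of methoxy on an aromatic carbon, para to a large group. In this assay no shift beyond the scatter is expected in either direction. The expected size is a number no higher from compound 2 to compound 3 (the limit leaves the size open) at most a small step. Compound 3 is estimated at 20000 nM with an expected range of 8000 nM to 40000 nM for now.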

Compound 3, half-maximal inhibitory concentration: > 20000 nM
Compound 3: no number, only a limit; the forecaster's own chance of this, stated with the estimate: 65%; the middle value sits exactly at the limit.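

Compound 3 gives > 20000 nM, a limit of the assay and not a number. No step can be read between compound 2 and compound 3: both values are limits. The compounds shown leave open which change to the shared core, if any, gives a measurable value in this assay.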